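The compounds below may be only part of what the source reports. "The series", "measured", "known", "first", "only" and "open" are said of these compounds alone.

Measured so far in an assay on isolated protein for displacement of a labelled ligand from melanin-concentrating hormone receptor 1 (Homo sapiens); on this read-out lower numbers stand for stronger inhibition and higher numbers for weaker inhibition:
- compound 1 `CCCc1ccc(/C=C/C(=O)Nc2ccc3nc(CCC)cc(N)c3c2)cc1`: 4 nM
- compound 2 `CCCc1cc(NC2CCC2)c2cc(NC(=O)/C=C/c3ccc(C(F)(F)F)cc3)ccc2n1`: 18 nM
- compound 3 `CCCc1cc(N2CCCC2)c2cc(NC(=O)/C=C/c3ccc(C(F)(F)F)cc3)ccc2n1`: 17 nM

Compound 1 shows the lowest number of the three; compound 2 and compound 3 both stand higher, and both gaps lie beyond the scatter. Compound 2 and compound 3 differ from compound 1 at two places at once, the group on the phenyl ring and the group on the shared core, so neither of them isolates the phenyl substituent. Among the compounds with values here, the only single-point step measured, a 1.1-fold lower number from compound 2 to compound 3 (0.02 log units; within the scatter), concerns the amine on the core and is within the scatter; it says nothing about the phenyl ring.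

Compound 4 `CCCc1cc(N)c2cc(NC(=O)/C=C/c3ccc(Br)cc3)ccc2n1` keeps the amino group of compound 1 and differs from it only by bromo in place of propyl on an aromatic carbon. Within the data shown here, no measured step bears on this exchange, so the expectation rests on compound 1 alone. The step of a 1.8-fold higher number from compound 1 to compound 4 (0.24 log units; within the scatter) is expected to be small, at most marginally beyond the scatter. For compound 4 in this assay a value of 7 nM is estimated, in the range 2 nM to 25 nM.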

Compound 4, half-maximal inhibitory concentration: 4 nM
The estimate for compound 4 lay 1.8-fold (0.24 log units) above the measured number, and the stated range covers the measured number.
By their numbers in this assay, from the lowest: compounds 1 and 4 (each within the scatter of the next); then compounds 3 and 2 (each within the scatter of the next).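

In this assay, within the data shown here, the change from 4-propylphenyl to 4-bromophenyl gives no change at the digits printed from compound 1 to compound 4 (within the scatter), the first reading in which this group moves alone while the amino group on the shared core stays fixed. At this position, on a six-membered aromatic ring of carbon only, a propyl chain of 3 carbon atoms and a single bromine atom therefore read alike, a comparison that compound 2 and compound 3 could not give, since each differs from compound 1 in two places. Nothing at hand offers an account of this equivalence.

Open, going by these compounds, is how a methoxy group, a chloro group, a carboxylic acid or a longer chain such as butyl would read here. Also open, on these data alone, is how trifluoromethyl reads with the amino group on the core, which would separate the phenyl substituent from the core amine in compound 2 and compound 3.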